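A few compounds are considered here, and "the series" means these few. Any claim that something is new, unique, unknown or untested is made for them only; others in the source may bear on it.

Measured so far:
- compound 1 `COc1ccc([C@H]2CC(=O)N(c3cccc(C)c3)C2)cc1OC1CCCC1` gives > 10000 nM in a functional assay on HEK293 cells (Homo sapiens) for cytotoxicity; on this read-out lower numbers stand for higher toxicity in this test and higher numbers for lower toxicity in this test; this is a limit of the assay, not a number.
- compound 2 `COc1ccc([C@H]2CC(=O)N(c3cccc(NCCCc4ccccc4)c3)C2)cc1OC1CCCC1` gives > 10000 nM in this assay; again only a limit.
- compound 3 `COc1ccc([C@H]2CC(=O)N(c3cccc(NS(=O)(=O)c4cccc(OC(F)(F)F)c4)c3)C2)cc1OC1CCCC1` gives > 10000 nM in this assay; again only a limit.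

Among the compounds with values here, the one step between measured compounds, a step that the two limits leave unreadable from compound 1 to compound 2, cannot be read, since both ends are limits. Compound 3 therefore stands nowhere distinct on the numbers: it sits at the limit of > 10000 nM in this assay, at which 3 of the 3 values shown sit, with no measured value above or below it to place it against.

Compound 4 `COc1ccc([C@H]2CC(=O)N(c3cccc(NS(=O)(=O)c4ccccc4C)c3)C2)cc1OC1CCCC1` differs from compound 3 at one place: 2-methylphenyl in place of 3-(trifluoromethoxy)phenyl on a sulfonyl sulfur. Within the data shown here, no measured step touches the sulfonyl substituent, and the only step is unreadable, so there is nothing in the data that points to a change in either direction in this assay. Among the measured compounds shown here, the expectation for compound 4 rests on compound 3 alone and on the fact that every value so far is a limit.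

Compound 4 is therefore expected to remain at the limit, and the step that the limit leaves unreadable from compound 3 to compound 4 is estimated as none beyond the scatter. The estimate for compound 4 in this assay is 15000 nM, with a range from 7000 nM to 40000 nM.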

Compound 4, half-maximal cytotoxic concentration: > 10000 nM
Compound 4: no number, only a limit; the forecaster's own chance of this, stated with the estimate: 85%; the middle value lies beyond the limit too.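

The steps from compound 1, compound 2 and compound 3 to compound 4 cannot be read in this assay, since each end is a limit: the limit of > 10000 nM in this assay, at which 4 of the 4 values shown sit. The compounds shown leave open whether any of these substituents changes cytotoxicity, and at what concentration any of the four compounds would become cytotoxic.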